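From a Cyclopropyl Primary Amide to a Dimethylamide

A few compounds are considered here, and "the series" means these few. Any claim that something is new, unique, unknown or untested is made for them only; others in the source may bear on it.

Compound 1 `CCOc1ccccc1-c1ccc(-c2nc3cnccc3c(NC(C(N)=O)C3CC3)c2C#N)cc1` stands highest of the two compounds measured in a physicochemical assay for lipophilicity, read by HPLC, at pH 7.5; on this read-out higher numbers stand for higher lipophilicity and lower numbers for lower lipophilicity: compound 1 gives 3, while compound 2 `CC[C@@H](Nc1c(C#N)c(-c2ccc(-c3ccncc3C)cc2)nc2cnccc12)C(N)=O` gives 2, a gap beyond the usual scatter. Compound 3 `CCOc1ccccc1-c1ccc(-c2nc3cnccc3c(N[C@H](CC)C(=O)N(C)C)c2C#N)cc1` differs from compound 1 on a nitrogen on an aromatic ring: a group of 8 heavy atoms (6 carbon, 1 nitrogen, 1 oxygen; no ring) in place of a group of 7 heavy atoms (5 carbon, 1 nitrogen, 1 oxygen; one three-membered non-aromatic ring of carbon only), on a nitrogen on an aromatic ring The entering 1-(dimethylcarbamoyl)propyl carries no hydrogen-bond donor. Among the compounds with values here, no measured pair shows this exact change, so the step is judged from the structures alone. In this assay the step from compound 1 to compound 3 is expected to be a modest rise, a number 0.60 log units higher from compound 1 to compound 3 (beyond the scatter). Compound 3 is estimated at 3.6, within 3.1 to 4.1.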

Compound 3, distribution coefficient: 3.7
The estimate for compound 3 lay 0.10 log units below the measured number; the range from low to high includes it.
By their numbers in this assay, from the lowest: compound 2; then compound 1; then compound 3.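

Within the data shown here, on a nitrogen on an aromatic ring, this exchange gives a number 0.70 log units higher from compound 1 to compound 3 (beyond the scatter) in this assay, the only step so far that can be read at this position. The entering 1-(dimethylcarbamoyl)propyl has no ring and no hydrogen-bond donor, while the leaving group has both, so this single step cannot assign the rise to either change. Nothing measured here explains the rise. On these data alone, it remains open how the number would move with a 1-(methylcarbamoyl)propyl group, or with a dimethylamide that keeps the cyclopropyl ring; either could help separate the two changes.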